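A few compounds are considered here, and "the series" means these few. Any claim that something is new, unique, unknown or untested is made for them only; others in the source may bear on it.

Compound 2 `Oc1cccc(-c2cc(-c3cccc(C(F)(F)F)c3)cc(-c3cccc(O)c3)n2)c1` was tested in a functional assay on T47D cells (Homo sapiens) for inhibition (on this read-out lower numbers stand for stronger inhibition and higher numbers for weaker inhibition), where compound 2 gives 4970 nM. Within the data shown here, only one other compound has been measured on the same read-out: compound 1 `Oc1cccc(-c2cc(-c3ccccc3F)cc(-c3cccc(O)c3)n2)c1`, which in this assay gives 4370 nM. The two numbers lie within the scatter of each other, so compound 2 cannot be told apart from compound 1 on this read-out; the step between them is a 1.1-fold higher number from compound 1 to compound 2 (0.06 log units; within the scatter).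

Compound 3 `Oc1cccc(-c2cc(-c3cccc(OC(F)(F)F)c3)cc(-c3cccc(O)c3)n2)c1` differs from compound 2 in one place: trifluoromethoxy in place of trifluoromethyl on an aromatic carbon. Among the measured compounds shown here, the only measured step that bears on this change, a 1.1-fold higher number from compound 1 to compound 2 (0.06 log units; within the scatter), also exchanged one fluorine-bearing group for another on a phenyl ring of the shared core and stayed within the scatter. For the measured compounds named here, no measured step shows a trifluoromethoxy group entering, so nothing in the data points to a shift in either direction. On that basis compound 3 is expected to show no step beyond the scatter in this assay, its estimated step being a 1.0-fold higher number from compound 2 to compound 3 (0.00 log units; within the scatter). The estimate for compound 3 in this assay is 5000 nM, with a range from 2200 nM to 11000 nM.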

Compound 3, half-maximal inhibitory concentration: 6740 nM
Compound 3: middle estimate off by 1.3-fold (0.13 log units), on the low side; the range from low to high includes it.
By their numbers in this assay, from the lowest: compounds 1, 2 and 3 (each within the scatter of the next).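

In this assay, among these compounds, the exchange of trifluoromethyl for trifluoromethoxy on an aromatic carbon, meta to a large group, gives a 1.4-fold higher number from compound 2 to compound 3 (0.13 log units; within the scatter), the first measured step in which this oxygen-linked group enters. The added oxygen, which brings one hydrogen-bond acceptor by the count of the two groups, therefore does not separate the two compounds on this read-out. With this result, the three fluorine-bearing substituents on this phenyl ring of the shared core form a chain of values in which each compound lies within the scatter of the next, so none of these exchanges has yet produced a step that can be read as a real difference. Nothing measured here speaks to any property of either group that could be connected with this result.

Whether this position can produce a step beyond the scatter at all remains open, since the compounds shown do not tell what an amine, a carboxylic acid or a longer chain would do there. They also leave open how the numbers would respond to a change in the hydroxyl groups of the shared core.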